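This account rests on a few compounds, and the source may have more. Where it says the series, first, only, none or still open, it means among the compounds named here.

Measured so far:
compound 1, `O=C(NS(=O)(=O)c1ccc(F)cc1)c1ccc(Nc2nc(NC3(c4ccc(Cl)cc4)CC3)nc(OCC(F)(F)F)n2)cc1`: 100%
compound 2, `CCS(=O)(=O)NC(=O)c1ccc(Nc2nc(NC3(c4ccc(Cl)cc4)CC3)nc(OCC(F)(F)F)n2)cc1`: 100%

In an ADME assay on microsomes from liver (Homo sapiens) for metabolic stability, with a stated time of 10 min (on this read-out higher numbers stand for a more stable compound and lower numbers for a less stable compound), compound 1 gives 100% and compound 2 gives 100%; compound 2 stands level with compound 1 at the digits shown, and the step of no change at the digits printed from compound 1 to compound 2 (within the scatter) lies within the scatter. Going by the values given here, that is the only measured step, and it swaps the group on the sulfonyl sulfur itself.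

Compound 3, `O=C(NS(=O)(=O)CCNCc1ccccc1)c1ccc(Nc2nc(NC3(c4ccc(Cl)cc4)CC3)nc(OCC(F)(F)F)n2)cc1`, is not yet measured. It differs from compound 2 by benzylamino in place of hydrogen on a saturated chain carbon, two bonds along the chain from a sulfonyl sulfur. Among the compounds with values here, no measured step covers a change of this kind: the one step available left the read-out unchanged, but it concerns a different part of the chain, so it gives only weak support for compound 3. With compound 2 already at the top of the scale, a rise cannot show; a step of a number 15 percentage points lower from compound 2 to compound 3 (beyond the scatter) is expected, most likely small. Compound 3 is estimated at 85%, in the range 55% to 100%.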

Compound 3, percent of the compound remaining: 99%
Beside the measured number, compound 3's estimate is 14 percentage points below it; low and high end bracket the measured number.
By their numbers in this assay, from the lowest: compounds 3, 1 and 2 (each within the scatter of the next).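

In this assay, the saturated chain carbon two bonds along the chain from a sulfonyl sulfur accepts benzylamino, with a number 1 percentage points lower from compound 2 to compound 3 (within the scatter). Until now only small or aromatic groups directly on the sulfonyl sulfur had been seen, whereas this change adds 8 heavy atoms, including a six-membered aromatic ring, and the larger replacement of 4-fluorophenyl by 2-(benzylamino)ethyl gives a number 1 percentage points lower from compound 1 to compound 3 (within the scatter). No measurement is available that bears on what lies behind this result.

All three compounds sit at or near the top of the scale, so any difference among them that this read-out cannot resolve stays hidden. Open too, as far as these compounds go, is whether a carboxylic acid, a dimethylamino group or a longer chain at the same place would give a similar read-out.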